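The source may report more compounds than this note shows. Statements on the series, on what has been measured and on what is new or still open speak of the compounds shown alone.

Compound 1 `Cc1ccc(-c2cn(-c3ccc(CN4CCN(C)CC4)c(C(F)(F)F)c3)nn2)cc1Nc1nccc(-c2cccnc2)n1` gives 1040 nM in a functional assay on KG-1a cells (Homo sapiens) for inhibition, read by MTT assay, with a stated time of 72 h (a higher number here means a weaker inhibitor, a lower number a stronger inhibitor), and compound 2 `Cc1ccc(-n2cc(-c3ccc(CN4CCN(C)CC4)c(C(F)(F)F)c3)nn2)cc1Nc1nccc(-c2cccnc2)n1` gives 1270 nM. Compound 3 `COc1ccc(-c2cn(-c3ccc(C)c(Nc4nccc(-c5cccnc5)n4)c3)nn2)cc1C(F)(F)F` gives 30000 nM, the highest of the three numbers, set apart from compound 2 by a 24-fold higher number from compound 2 to compound 3 (1.37 log units; beyond the scatter). Compound 4 `Cc1ccc(-n2cc(CCO)nn2)cc1Nc1nccc(-c2cccnc2)n1` is not yet measured; it differs from compound 3 by 2-hydroxyethyl in place of 4-methoxy-3-(trifluoromethyl)phenyl on an aromatic carbon. Among the measured compounds shown here, no measured step covers this change, since the only measured step concerns the methoxy and (4-methylpiperazin-1-yl)methyl groups; the weak number of compound 3 is the nearest guide. Compound 4 is therefore expected to stay in the weak range, with an estimated step of a 1.5-fold lower number from compound 3 to compound 4 (0.18 log units; within the scatter). The estimated value of compound 4 is 20000 nM, between 4000 nM and 80000 nM.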

Compound 4, half-maximal inhibitory concentration: 6540 nM
Compound 4: the middle estimate sits 3.1-fold (0.49 log units) above what was measured; measured number inside the range.
By their numbers in this assay, from the lowest: compounds 1 and 2 (each within the scatter of the next); then compound 4; then compound 3.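

Putting 2-hydroxyethyl in place of 4-methoxy-3-(trifluoromethyl)phenyl on this aromatic carbon of the five-membered ring gives a 4.6-fold lower number from compound 3 to compound 4 (0.66 log units; beyond the scatter) in this assay for this change. The six-membered aromatic ring of the leaving group is therefore not needed here for the activity compound 4 retains, and a small chain without a ring is tolerated. Nothing in the data explains this step.

Going by these compounds, whether the gain depends on the hydroxyl or on the removal of the aromatic ring stays open. An ethyl chain, a longer alcohol chain, an amine or a carboxylic acid at this carbon would help separate those two readings.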